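Swapping 1-bromoethyl for ethynyl on a carbonyl carbon

The compounds below may be only part of what the source reports. "The series", "measured", "known", "first", "only" and "open" are said of these compounds alone.

Values from a functional assay on KYSE-450 cells (Homo sapiens) for inhibition, read by MTT assay, with a stated time of 48 h (on this read-out lower numbers stand for stronger inhibition and higher numbers for weaker inhibition), follow
- Compound 1 `COCC(=O)N(Cc1ccc(OC)c(O)c1)c1cc(OC)c(OC)c(OC)c1` gives 460 nM
- Compound 2 `COc1ccc(CN(C(C)=O)c2cc(OC)c(OC)c(OC)c2)cc1O` gives 160 nM
- Compound 3 `COc1ccc(CN(C(=O)C(C)Br)c2cc(OC)c(OC)c(OC)c2)cc1O` gives 160 nM

Compound 3 sits at the low end of these numbers: one comparison shows no movement (no change at the digits printed from compound 2 to compound 3 (within the scatter)), the other a modest drop (a 2.9-fold lower number from compound 1 to compound 3 (0.46 log units; beyond the scatter)). Compound 4 `C#CC(=O)N(Cc1ccc(OC)c(O)c1)c1cc(OC)c(OC)c(OC)c1` differs from it in one group (ethynyl in place of 1-bromoethyl on a carbonyl carbon), with ethynyl in place of 1-bromoethyl on a carbonyl carbon. Changes at this carbonyl carbon have so far stayed modest (a 2.9-fold lower number from compound 1 to compound 2 (0.46 log units; beyond the scatter)). For the measured compounds named here, no measured compound carries ethynyl, so the direction stays open. The step expected in this assay is therefore small (a 1.1-fold higher number from compound 3 to compound 4 (0.05 log units; within the scatter)), with none expected beyond the scatter. Compound 4 is estimated at 180 nM (expected range 50 nM to 600 nM).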

Compound 4, half-maximal inhibitory concentration: 570 nM
Estimate against measurement, compound 4: 3.2-fold (0.50 log units) below; the measured number falls inside the stated range.
By their numbers in this assay, from the lowest: compounds 2 and 3 (each within the scatter of the next); then compounds 1 and 4 (each within the scatter of the next).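

In this assay, for the compounds shown here, the group on this carbonyl carbon matters more than the earlier compounds could show: ethynyl does not match methyl (a 3.6-fold higher number from compound 2 to compound 4 (0.55 log units; beyond the scatter)) or 1-bromoethyl (a 3.6-fold higher number from compound 3 to compound 4 (0.55 log units; beyond the scatter)), two groups that had given the same number. Ethynyl and methoxymethyl, however, cannot be told apart (a 1.2-fold higher number from compound 1 to compound 4 (0.09 log units; within the scatter)), so the ranking does not simply follow the heavy-atom count of the group. Nothing measured here explains these differences.

On these data alone, how a longer chain such as propyl, or an amine such as dimethylaminomethyl, would behave on this carbonyl carbon remains open.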